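This account rests on a few compounds, and the source may have more. Where it says the series, first, only, none or still open, it means among the compounds named here.

Measured in a functional assay on RAW264.7 cells (Mus musculus) for inhibition, read by spectrophotometry and Griess assay, with a stated time of 24 h; on this read-out lower numbers stand for stronger inhibition and higher numbers for weaker inhibition:
Compound 1 `COc1cc(CCC(=O)C[C@@H](O)CCc2ccc(O)cc2)ccc1O` gives 37500 nM.
Compound 3 `O=C(CCc1ccc(O)cc1)C[C@@H](O)CCc1ccc(O)cc1` gives 46400 nM.
Compound 2 `Oc1ccc(CC[C@@H](O)C[C@H](O)CCc2ccc(O)cc2)cc1` reaches only a limit of the assay, > 100000 nM.

Compound 1 stands at the lower of the two numbers shown in this assay, but the step of a 1.2-fold higher number from compound 1 to compound 3 (0.09 log units; within the scatter) is within the scatter, so compound 1 and compound 3 cannot be ordered. Compound 2 sits at the limit of > 100000 nM in this assay, at which 1 of the 3 values shown sits.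

Compound 4 `COc1cc(CCC(=O)C[C@@H](O)CCc2ccc(O)c(O)c2)ccc1O` differs from compound 1 by hydroxy in place of hydrogen on an aromatic carbon, read one bond further out as 4-hydroxyphenyl to 3,4-dihydroxyphenyl. Among the compounds with values here, no measured step carries this change; the only measured single-point step, methoxy to hydrogen, stayed within the scatter. A step of about the scatter, at most a modest move to a lower number, is expected: a 1.5-fold lower number from compound 1 to compound 4 (0.18 log units; within the scatter). Compound 4 is therefore estimated near 25000 nM, within 10000 nM to 60000 nM.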

Compound 4, half-maximal inhibitory concentration: 9370 nM
Beside the measured number, compound 4's estimate is 2.7-fold (0.43 log units) above it, and the stated range ends above it.
By their numbers in this assay, from the lowest: compound 4; then compounds 1 and 3 (each within the scatter of the next). At a limit, above all of these: compound 2.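

In this assay, hydroxy on this aromatic carbon, ortho to a hydroxy group, gives a step beyond the scatter: a 4.0-fold lower number from compound 1 to compound 4 (0.60 log units; beyond the scatter). Within the data shown here, the earlier single-place step, a 1.2-fold higher number from compound 1 to compound 3 (0.09 log units; within the scatter), did not separate its pair, so 4-hydroxyphenyl to 3,4-dihydroxyphenyl is the first change here to move the number. Nothing shown bears on the reason for this step.

Open, going by these compounds, is whether hydroxy itself is needed at this carbon, or whether methoxy, fluorine or an amine there would give a similar step. Also open, on these data alone, is whether the same change would give a similar step on compound 3.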